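The source may hold more compounds than are shown below. What is called first, only, known or untested is meant among the compounds shown, and "the series" means these compounds.

Of the compounds shown here, two with the shared core have been measured in a functional assay on MCF7 cells (Homo sapiens) for inhibition, read by MTT assay, with a stated time of 24 h; a higher number here means a weaker inhibitor, a lower number a stronger inhibitor. Compound 1 `CCOC(=O)C1=Cc2ccccc2OC1(OCc1cn(-c2ccc(F)cc2)nn1)C(F)(F)F` gives 9100 nM in this assay. Compound 2 `Cc1ccc(-c2cc(COC3(C(F)(F)F)Oc4ccccc4C=C3C(=O)O)on2)cc1` gives 30100 nM in this assay, a higher number than compound 1 by a margin beyond the scatter, so that compound 1 holds the lowest number of the two. Compound 3 `CCOC(=O)C1=Cc2ccccc2OC1(OCc1cn(CC(=O)Nc2ccccc2F)nn1)C(F)(F)F` is not yet measured in this assay. It differs from compound 1 in one place: ((2-fluorophenyl)carbamoyl)methyl in place of 4-fluorophenyl on an aromatic nitrogen. Within the data shown here, no step between measured compounds follows this change, so the data give no direct guide to its size. The step from compound 1 to compound 3 in this assay is expected to be small, toward a higher number, and within the scatter: a 1.3-fold higher number from compound 1 to compound 3 (0.12 log units; within the scatter). Compound 3 is thus estimated to give 12000 nM in this assay, with a range from 4000 nM to 40000 nM.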

Compound 3, half-maximal inhibitory concentration: 42100 nM
The estimate for compound 3 lay 3.5-fold (0.55 log units) below the measured number; measured number outside the range, above it.
By their numbers in this assay, from the lowest: compound 1; then compounds 2 and 3 (each within the scatter of the next).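

On the aromatic nitrogen of the five-membered ring, ((2-fluorophenyl)carbamoyl)methyl in place of 4-fluorophenyl gives a 4.6-fold higher number from compound 1 to compound 3 (0.67 log units; beyond the scatter) in this assay, so the change weakens inhibition by a margin beyond the scatter. Among these compounds, this is the first step in the set that isolates a single place, and it shows that the group on this nitrogen affects the read-out. Nothing available explains the step, and which part of the change is responsible remains unknown.

The compounds shown do not separate the effect of the amide from that of the 2-fluorophenyl ring or of the inserted chain. On these data alone, it also remains open how a benzyl group, a simple amine-bearing chain or a longer alkyl chain on the same nitrogen would read in this assay.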